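Pulling the fluorophenyl onto the amide carbonyl

The compounds below may be only part of what the source reports. "The series", "measured", "known", "first", "only" and "open" are said of these compounds alone.

Measured so far:
compound 1 `CC(C)CCC(=O)N[C@@H](C(=O)N1CCC(c2ccc(Cl)cc2)CC1)C(C)C`: 26 nM
compound 2 `CC(C)[C@@H](NC(=O)CCc1ccc(F)cc1)C(=O)N1CCC(c2ccc(Cl)cc2)CC1`: 70 nM

In an assay on THP-1 cells for displacement of a labelled ligand from C-C chemokine receptor type 1 (Homo sapiens) (a lower number here means a stronger inhibitor, a higher number a weaker inhibitor), compound 1 gives 26 nM, and compound 2 gives 70 nM, the higher of the two numbers. Among the compounds with values here, the single measured step, a 2.7-fold higher number from compound 1 to compound 2 (0.43 log units; beyond the scatter), is modest but beyond the scatter.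

Compound 3 `CC(C)[C@@H](NC(=O)c1cccc(F)c1)C(=O)N1CCC(c2ccc(Cl)cc2)CC1` is the next step from compound 2: 3-fluorophenyl in place of 2-(4-fluorophenyl)ethyl on a carbonyl carbon. The aromatic ring now sits directly on the amide carbonyl, with the two-carbon chain gone and the fluorine moved to a different ring position. Within the data shown here, no measured step bears on removing that chain, and only a 2.7-fold higher number from compound 1 to compound 2 (0.43 log units; beyond the scatter) shows how this end of the molecule tolerates change, which was a modest loss. A modest further weakening, or none beyond the scatter, is therefore expected.

Compound 3 is estimated at 150 nM, with a range from 40 nM to 600 nM. This estimate means an expected step of a 2.1-fold higher number from compound 2 to compound 3 (0.33 log units; beyond the scatter).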

Compound 3, half-maximal inhibitory concentration: 24 nM
For compound 3 the middle estimate is 6.3-fold (0.80 log units) above the measured one, and the stated range ends above it.
By their numbers in this assay, from the lowest: compounds 3 and 1 (each within the scatter of the next); then compound 2.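

In this assay, the change to 3-fluorophenyl gives a 2.9-fold lower number from compound 2 to compound 3 (0.46 log units; beyond the scatter), so a fluorinated aromatic ring is tolerated better on the carbonyl carbon itself than at the end of the 2-(4-fluorophenyl)ethyl group. The comparison with the isopentyl group gives a 1.1-fold lower number from compound 1 to compound 3 (0.03 log units; within the scatter), showing that an aromatic ring at this place need not cost anything, although compound 2 , which also carries one, remains the exception among these three compounds. No evidence here explains this result.

Two things changed together from compound 2 to compound 3 , the ethyl link and the fluorine's ring position, and the compounds shown cannot separate their contributions. From the compounds shown here alone, it also remains open how 4-fluorophenyl, a plain phenyl without fluorine, or a phenyl carrying a carboxylic acid would fare on this carbonyl carbon.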